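Working notes: azole swap on a methylamino amide core

The source may hold more compounds than are shown below. What is called first, only, known or untested is meant among the compounds shown, and "the series" means these compounds.

Compound 1 `CCCCCOC(=O)C(C)(C)C(c1ccc(Nc2ccc3ccccc3c2)cc1)n1ccnc1` carries a pentyloxy group on the carbonyl carbon of its side chain, and in an assay on isolated protein for inhibition of cytochrome P450 26A1 (Homo sapiens), read by scintillation counting (on this read-out lower numbers stand for stronger inhibition and higher numbers for weaker inhibition), compound 1 gives 140 nM. Compound 2 `CC(C)(C(N)=O)C(c1ccc(Nc2ccc3ccccc3c2)cc1)n1ccnc1` has an amino group in that place, and in this assay compound 2 gives 50 nM. Compound 3 `CNC(=O)C(C)(C)C(c1ccc(Nc2ccc3ccccc3c2)cc1)n1ccnc1` bears a methylamino group there, and in this assay compound 3 gives 12 nM. The steps among them are a 2.8-fold lower number from compound 1 to compound 2 (0.45 log units; beyond the scatter), a 12-fold lower number from compound 1 to compound 3 (1.07 log units; beyond the scatter) and a 4.2-fold lower number from compound 2 to compound 3 (0.62 log units; beyond the scatter), so compound 3 stands lowest of the three numbers, with compound 2 nearest and compound 1 furthest from it. Compound 4 `CNC(=O)C(C)(C)C(c1ccc(Nc2ccc3ccccc3c2)cc1)n1cncn1` keeps the methylamino carbonyl side chain of compound 3 and differs from it only by 1H-1,2,4-triazol-1-yl in place of 1H-imidazol-1-yl on a saturated chain carbon bound to an aromatic carbon and a saturated chain carbon. Within the data shown here, none of the three measured steps touches this position; all three concern the group on the carbonyl carbon, so no measured step bears directly on the change. The data give no ground for a direction, and the expected step is a 1.7-fold higher number from compound 3 to compound 4 (0.22 log units; within the scatter), which is not expected to pass beyond the scatter, though the range must stay wide. Compound 4 is therefore estimated in this assay at 20 nM, between 6 nM and 70 nM.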

Compound 4, half-maximal inhibitory concentration: 350 nM
Compound 4: the middle estimate sits 18-fold (1.24 log units) below what was measured; the measured number lies above the stated range.
By their numbers in this assay, from the lowest: compound 3; then compound 2; then compound 1; then compound 4.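

Among these compounds, the azole position is the first place to be read apart from the group on the carbonyl carbon, and it proves highly sensitive: with the methylamino carbonyl side chain held fixed, 1H-1,2,4-triazol-1-yl in place of 1H-imidazol-1-yl gives in this assay a 29-fold higher number from compound 3 to compound 4 (1.46 log units; beyond the scatter). The change is small on paper, as both rings have 5 heavy atoms and neither has a hydrogen-bond donor, and the entering ring differs only by one nitrogen in place of one carbon and by one further hydrogen-bond acceptor, so an exchange of a single ring atom on the saturated chain carbon is enough to produce a large step. No measurement at hand accounts for the size of this step.

The compounds shown leave open whether the same swap costs as much when the carbonyl carbon carries amino or pentyloxy, since the triazole is seen only with the methylamino side chain. They also leave open how other groups on this carbon, such as a pyrazolyl ring, a tetrazolyl ring or a primary amine, would read in this assay.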